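Methoxycarbonyl to ethoxycarbonyl: compound 3 to compound 4

A few compounds are considered here, and "the series" means these few. Any claim that something is new, unique, unknown or untested is made for them only; others in the source may bear on it.

Three compounds of the series have numbers in an assay on a protein complex for inhibition of CDK8/Cyclin C (Homo sapiens), with a stated time of 1 h, tested at 10 uM; on this read-out lower numbers stand for less inhibition and higher numbers for more inhibition at the one concentration tested (going by the name of the read-out). Compound 1 `CCOC(=O)/C=C/c1ccncc1-c1ccc2[nH]ccc2c1` gives 100% in this assay. Compound 2 `Cn1ncc2cc(-c3cnccc3/C=C/C(=O)N3CCOCC3)ccc21` gives 95% in this assay. Compound 3 `COC(=O)/C=C/c1ccncc1-c1ccc2ccccc2c1` gives 102% in this assay, the highest of the three numbers; its nearest neighbour is compound 1, lower by an amount within the scatter, and the furthest is compound 2, also lower by an amount within the scatter. The three numbers are therefore indistinguishable at the concentration tested, and no order among compounds 1, 2 and 3 can be read from them.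

Compound 4 `CCOC(=O)/C=C/c1ccncc1-c1ccc2ccccc2c1` has not yet been measured in this assay. It differs from compound 3 in one place only: methyl in place of hydrogen on a saturated chain carbon bound to an oxygen next to a carbonyl group. Going by the values given here, no measured pair isolates this change, so there is nothing to lean on beyond the values themselves.

Given that compound 3 is already at the top of the read-out with 102%, the step of a number 2 percentage points lower from compound 3 to compound 4 (within the scatter) is expected to be none beyond the scatter. For compound 4 the estimate in this assay is 100%, with a range from 90% to 108%.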

Compound 4, a percentage reported as inhibition, at one concentration (the size of the read-out at that concentration, not a potency): 102%
Beside the measured number, compound 4's estimate is 2 percentage points below it; the measured number falls inside the stated range.
By their numbers in this assay, from the lowest: compounds 2, 1, 3 and 4 (each within the scatter of the next).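

Methoxycarbonyl to ethoxycarbonyl gives no change at the digits printed from compound 3 to compound 4 (within the scatter) in this assay, and this is the first pair in the series that isolates a change at this position. At the one concentration tested, the saturated chain on the oxygen next to the carbonyl group can therefore carry an ethyl as well as a methyl without a change beyond the scatter, although both numbers stand at the top of the read-out and say nothing about potency. No available measurement accounts for this result.

It remains open whether this position also holds the read-out with a longer chain on the same oxygen, or with a carboxylic acid or an amine in place of the ester group, since the step shown covers only the move from methyl to ethyl. As far as these compounds go, it also remains open whether compound 3 and compound 4 would separate at lower concentrations, where the read-out would no longer stand at its top and a difference between the two could show.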